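Removing the Methyl from Compound 2: What to Expect

The source may hold more compounds than are shown below. What is called first, only, known or untested is meant among the compounds shown, and "the series" means these compounds.

Of the compounds shown here, two have been measured in an assay on isolated protein for inhibition of Polyunsaturated fatty acid 5-lipoxygenase (Homo sapiens), tested at 10 uM; on this read-out higher numbers stand for more inhibition at the one concentration tested (going by the name of the read-out) and lower numbers for less inhibition.
Compound 1, `CCOC(=O)c1c(NC(C)c2ccccc2)[nH]c2ccc(O)cc12`, gives 72%.
Compound 2, `CCOC(=O)c1c(NC(C)c2ccccc2)n(C)c2ccccc12`, gives 42%.

Compound 2 stands lowest of the two numbers; its nearest neighbour is compound 1, whose value is higher by a gap beyond the usual scatter. Compound 1 and compound 2 differ in two places at once, so their two values cannot be tied to a single change.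

Compound 3, `CCOC(=O)c1c(NC(C)c2ccccc2)[nH]c2ccccc12`, differs from compound 2 by hydrogen in place of methyl on an aromatic nitrogen. Going by the values given here, no measured pair shows this change alone, so the direction of the step rests on the fact that compound 1, the higher of the two, also carries hydrogen on that nitrogen. A modest rise from compound 2 is expected, a number 13 percentage points higher from compound 2 to compound 3 (beyond the scatter), but it could also fall within the scatter. Compound 3 is therefore estimated at 55% in this assay, with a range from 35% to 75%.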

Compound 3, a percentage reported as inhibition, at one concentration (the size of the read-out at that concentration, not a potency): 51%
Compound 3: the middle estimate sits 4 percentage points above what was measured; the range from low to high includes it.
By their numbers in this assay, from the lowest: compounds 2 and 3 (each within the scatter of the next); then compound 1.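

In this assay, going by these compounds alone, hydrogen in place of methyl on the aromatic nitrogen gives a number 9 percentage points higher from compound 2 to compound 3 (within the scatter), so with only this one change, the two groups on that nitrogen cannot be told apart. Hydrogen in place of hydroxy on an aromatic carbon, by contrast, gives a number 21 percentage points lower from compound 1 to compound 3 (beyond the scatter), which is the first single change in this set to produce a clear difference. Of the two places in which compound 1 and compound 2 differ, only the hydroxy step therefore lies beyond the scatter.

Going by these compounds, it remains open whether a methoxy group or an amine at the hydroxy position, or an ethyl group on the aromatic nitrogen, would give a different value. Nothing measured here explains the size of either step.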